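A few compounds are considered here, and "the series" means these few. Any claim that something is new, unique, unknown or untested is made for them only; others in the source may bear on it.

Compound 1 `COc1ccc(-c2nc(CC(=O)c3cccc(Cl)c3)nc3ccsc23)cn1` is one of three closely related compounds that have been tested in an ADME assay on cells (Homo sapiens) for cytotoxicity, read by resazurin assay, with a stated time of 5 days; on this read-out lower numbers stand for higher toxicity in this test and higher numbers for lower toxicity in this test. In this assay compound 1 gives 30000 nM, the lowest of the two numbers reported, which marks it as the more toxic of the two in this test. Compound 3 `COc1ccc(-c2nc(CS(=O)(=O)c3cccc(Cl)c3)nc3ccsc23)cc1` gives 69000 nM in this assay, a gap from compound 1 that lies beyond the usual scatter. For compound 2 `COc1ccc(-c2nc(C3(S(=O)(=O)c4cccc(Cl)c4)CC3)nc3ccsc23)cn1` this assay reports only a limit, > 50000 nM, and no number (the limit of > 50000 nM in this assay, at which 1 of the 3 values shown sits). Compound 4 `COc1ccc(-c2nc(C[S+]([O-])c3cccc(Cl)c3)nc3ccsc23)cn1` has not yet been tested. It differs from compound 1 in a single place: a group of 9 heavy atoms (6 carbon, 1 oxygen, 1 sulfur, 1 chlorine; one six-membered aromatic ring of carbon only) in place of a group of 9 heavy atoms (7 carbon, 1 oxygen, 1 chlorine; one six-membered aromatic ring of carbon only), on a saturated chain carbon bound to an aromatic carbon. For the measured compounds named here, no pair of measured compounds shows this step directly, so its size can only be estimated; the expectation is a modest move toward lower toxicity, of a size that may just reach beyond the scatter, since compound 3 gives 69000 nM. Compound 4 is therefore estimated at 50000 nM, between 20000 nM and 110000 nM, which means an expected step of a 1.7-fold higher number from compound 1 to compound 4 (0.22 log units; within the scatter).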

Compound 4, half-maximal cytotoxic concentration: > 50000 nM
Compound 4: only a limit was reported; the forecaster's own chance of this, stated with the estimate: 40%; the middle value lies on the limit itself.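

For the compounds shown here, compound 4 gives the first direct reading of a change at this position in this assay: a sulfur-containing group in place of the (3-chlorophenyl)carbonyl group of compound 1, on a saturated chain carbon bound to an aromatic carbon. For compound 4 the assay reports only a limit, > 50000 nM. This gives an at least 1.6-fold higher number from compound 1 to compound 4 (0.22 log units; that floor lies within the scatter), so the change brings no higher toxicity in this test, but its size cannot be fixed, since the reading ends at a limit: the limit of > 50000 nM in this assay, at which 2 of the 4 values shown sit.

Going by these compounds, it remains open how far the true number for compound 4 lies from that limit, and so whether the step truly reaches beyond the usual scatter. Also open, on these data alone, is how other groups at this place, such as an amine or a longer chain, would read in this assay.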